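The source may hold more compounds than are shown below. What is called first, only, known or untested is meant among the compounds shown, and "the series" means these compounds.

For the measured compounds named here, in an ADME assay on L6 cells (Rattus norvegicus) for cytotoxicity (on this read-out lower numbers stand for stronger inhibition and higher numbers for weaker inhibition), three compounds that share one core have numbers so far. Compound 1 `CCN(CC)CC(=O)OC1CC2(N3CCCC3)CC(c3ccccc3)C1C(c1ccccc1)C2` gives 49000 nM, compound 2 `O=C(CN1CCCCC1)OC1CC2(N3CCCC3)CC(c3ccccc3)C1C(c1ccccc1)C2` gives 14200 nM, and compound 3 `CCN(CC)CCC(=O)OC1CC2(N(C)C)CC(c3ccccc3)C1C(c1ccccc1)C2` gives 23600 nM. Compound 3 thus lies within the usual scatter of compound 2, and its number is lower than that of compound 1, though only just beyond the scatter.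

Compound 4 `CCN(CC)CCC(=O)OC1CC2(N3CCCC3)CC(c3ccccc3)C1C(c1ccccc1)C2` alters a single group of compound 3: pyrrolidin-1-yl in place of dimethylamino on a saturated ring carbon. Put simply, pyrrolidin-1-yl takes the place of dimethylamino on a saturated ring carbon.

Going by the values given here, no measured step makes this exact exchange. The closest guide is a 3.5-fold lower number from compound 1 to compound 2 (0.54 log units; beyond the scatter), a modest step in which piperidin-1-yl replaced diethylamino. There, too, a ring-bearing amino group replaced one without a ring, but on a saturated chain carbon bound to a carbonyl carbon, not on the ring carbon that changes here. That single step, made elsewhere in the molecule, is weak evidence. In this assay, a small move towards a lower number is therefore expected, most likely one that stays within the scatter. The expected change is a 1.4-fold lower number from compound 3 to compound 4 (0.14 log units; within the scatter). Compound 4 is estimated at about 17000 nM, with an expected range from 7000 nM to 42000 nM.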

Compound 4, half-maximal inhibitory concentration: 19200 nM
For compound 4 the middle estimate is 1.1-fold (0.05 log units) below the measured one; low and high end bracket the measured number.
By their numbers in this assay, from the lowest: compounds 2, 4 and 3 (each within the scatter of the next); then compound 1.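

In this assay, replacing dimethylamino with the ring-bearing pyrrolidin-1-yl on this saturated ring carbon (a 1.2-fold lower number from compound 3 to compound 4 (0.09 log units; within the scatter)) produces a difference that cannot be told apart from repeat-measurement noise, so this exchange at this position has no readable effect on the number. With pyrrolidin-1-yl held in place, the ester side chain gives a mixed picture: (diethylamino)methyl in place of diethylamino (a 2.6-fold lower number from compound 1 to compound 4 (0.41 log units; beyond the scatter)) is a modest step beyond the scatter, whereas (diethylamino)methyl in place of piperidin-1-yl (a 1.4-fold higher number from compound 2 to compound 4 (0.13 log units; within the scatter)) stays within it, so the side chain, not the ring carbon, is the only place among these new steps where a change can be read. No measurement here offers a reason for any of these steps.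

For the compounds shown here, these compounds do not show whether a morpholin-4-yl or azepan-1-yl group on the same ring carbon would also leave the number in place, since only two amino groups have been compared there. They also leave open how a longer chain between the ester carbonyl and the diethylamino group would read in this assay.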